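From a silicon group to a triazole on one carbon

A few compounds are considered here, and "the series" means these few. Any claim that something is new, unique, unknown or untested is made for them only; others in the source may bear on it.

Measured in a functional assay on SW480 cells (Homo sapiens) for antiproliferative activity, read by MTT assay, with a stated time of 48 h; a higher number here means a weaker inhibitor, a lower number a stronger inhibitor:
Compound 1 `CC(C)=CCC[C@]1(C)/C=C/[C@@H](OC(=O)C=C(C)C)[C@](C)(O)/C=C/C(=O)/C(C(=O)O)=C\C1`: > 10000 nM
Compound 2 `CC(C)=CCC[C@]1(C)/C=C/[C@@H](OC(=O)C=C(C)C)[C@](C)(O)/C=C/C(=O)/C(CN(C(C)C)C(C)C)=C\C1`: 750 nM
Compound 3 `CC[Si](CC)(CC)C/C1=C/C[C@](C)(CCC=C(C)C)/C=C/[C@@H](OC(=O)C=C(C)C)[C@](C)(O)/C=C/C1=O`: 2690 nM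

Compound 1 has an entry (> 10000 nM) that is a limit of the assay and not a number. Compound 3 (2690 nM) has the higher of the two true numbers, and the gap to the other one, a 3.6-fold higher number from compound 2 to compound 3 (0.55 log units; beyond the scatter), lies beyond the scatter.

Compound 4 `CC(C)=CCC[C@]1(C)/C=C/[C@@H](OC(=O)C=C(C)C)[C@](C)(O)/C=C/C(=O)/C(Cn2cc(CO)nn2)=C\C1` keeps the shared core and differs in one group (a group of 7 heavy atoms (3 carbon, 3 nitrogen, 1 oxygen; one five-membered aromatic ring with 3 hetero atoms) in place of a group of 7 heavy atoms (6 carbon, 1 silicon; no ring), on a saturated chain carbon bound to a double-bonded ring carbon). The new group is 4-(hydroxymethyl)-1H-1,2,3-triazol-1-yl, on a saturated chain carbon bound to a double-bonded ring carbon.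

The closest evidence is the modest step already given, because a 3.6-fold higher number from compound 2 to compound 3 (0.55 log units; beyond the scatter) swapped groups at this same place. Two further steps, an at least 13-fold lower number from compound 1 to compound 2 (1.12 log units; beyond the scatter) and an at least 3.7-fold lower number from compound 1 to compound 3 (0.57 log units; beyond the scatter), are large and at least modest, but both start from a limit. Among the measured compounds shown here, no measured compound carries a triazole, so the data give no direction.

In this assay the estimated step is a 1.1-fold higher number from compound 3 to compound 4 (0.05 log units; within the scatter) (expected to stay within the scatter, with a wide margin either way). The expected value for compound 4 is 3000 nM (estimated range 800 nM to 10000 nM).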

Compound 4, half-maximal inhibitory concentration: 2870 nM
The estimate for compound 4 lay 1.0-fold (0.02 log units) above the measured number, and the stated range covers the measured number.
By their numbers in this assay, from the lowest: compound 2; then compounds 3 and 4 (each within the scatter of the next). At a limit, above all of these: compound 1.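

Replacing the silicon-bearing group with 4-(hydroxymethyl)-1H-1,2,3-triazol-1-yl on this saturated chain carbon in this assay gives a 1.1-fold higher number from compound 3 to compound 4 (0.03 log units; within the scatter) and so shows something new: a group with no ring and no hydrogen-bond donors or acceptors and a group with a five-membered aromatic ring, a donor and acceptors can sit at this place without the number moving beyond the scatter. The diisopropylamino group of compound 2 now stands apart from both of these groups, with the triazole giving a 3.8-fold higher number from compound 2 to compound 4 (0.58 log units; beyond the scatter) and thus the same kind of gap that compound 3 showed. The comparison with the carboxy group gives an at least 3.4-fold lower number from compound 1 to compound 4 (0.54 log units; beyond the scatter) but starts from compound 1, whose entry is a limit and not a number: the limit of > 10000 nM in this assay, at which 1 of the 4 values shown sits.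

One triazole cannot separate the ring from its hydroxymethyl group, so a triazole carrying a plain methyl or a longer chain would be needed to tell them apart. On these data alone, whether the lower number of compound 2 extends to other amines, such as dimethylamino or piperidine at this place, also stays open.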